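The source may hold more compounds than are shown below. What is called first, only, known or untested is meant among the compounds shown, and "the series" means these compounds.

Among the measured compounds shown here, compound 2 `O=c1cc(Cn2ccnc2)c2ccc(OCc3cccc(F)c3)cc2o1` gives 200 nM in an assay on V79MZh11B2 cells for inhibition of cytochrome P450 11B2, mitochondrial (Homo sapiens), read by HPLC, with a stated time of 25 min (on this read-out higher numbers stand for weaker inhibition and lower numbers for stronger inhibition), the highest of the two numbers so far; compound 1 `COc1ccc(COc2ccc3c(Cn4ccnc4)cc(=O)oc3c2)cc1`, with 124 nM, differs by a 1.6-fold higher number from compound 1 to compound 2 (0.21 log units; within the scatter). Compound 3 `Cc1cccc(COc2ccc3c(Cn4ccnc4)cc(=O)oc3c2)c1` carries methyl in place of fluoro on an aromatic carbon, which, cut one bond further out, reads 3-fluorobenzyl to 3-methylbenzyl. For the measured compounds named here, the only measured step, from compound 1 to compound 2, swapped a whole aryl group and stayed within the scatter, so the smaller swap here is expected to move the number by no more than a 1.1-fold lower number from compound 2 to compound 3 (0.05 log units; within the scatter). Compound 3 is therefore estimated at 180 nM, within 80 nM to 400 nM.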

Compound 3, half-maximal inhibitory concentration: 250 nM
Compound 3: the middle estimate sits 1.4-fold (0.14 log units) below what was measured, within the range that was stated.
By their numbers in this assay, from the lowest: compounds 1, 2 and 3 (each within the scatter of the next).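

In this assay, methyl in place of fluoro on this aromatic carbon gives a 1.3-fold higher number from compound 2 to compound 3 (0.10 log units; within the scatter), so this exchange of one heavy atom for another does not separate the two compounds. The wider exchange of 4-methoxyphenyl for 3-methylphenyl gives a 2.0-fold higher number from compound 1 to compound 3 (0.30 log units; within the scatter), so all three aryl groups shown remain indistinguishable here. No supporting data explain this result. Open, going by these compounds, is whether an amine, a carboxylic acid or a longer chain on this ring would move the number beyond the scatter. Also open, on these data alone, is whether methyl or fluoro would read the same elsewhere on the ring.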